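Chloro for methyl on the aryl ring of compound 3

The source may hold more compounds than are shown below. What is called first, only, known or untested is meant among the compounds shown, and "the series" means these compounds.

Series of small bicyclic and related aryl-substituted compounds, read in a functional assay on T47D cells (Homo sapiens) for cytotoxicity, with a stated time of 72 h, tested at 50 ug/mL; a higher number here means a stronger effect of the compound at the concentration tested, a lower number a weaker effect. Compound 1 `O=c1[nH]nc2n(c1=O)CCN2c1ccccc1` gives 0% in this assay. Compound 2 `N/N=C1\NCCN1c1ccccc1Cl` gives 27% in this assay. Compound 3 `Cc1ccc(N2CCn3c2n[nH]c(=O)c3=N)cc1` gives 0% in this assay.

Compound 3 stands level with compound 1 at the digits recorded; the two together sit at the bottom of the three numbers, and the gap between them lies within the scatter, so no order can be read between them. Compound 2 is the nearest point of contrast: its number is above that of compound 3 by a margin beyond the scatter.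

Compound 4 `N=c1c(=O)[nH]nc2n1CCN2c1ccc(Cl)cc1` is not yet measured in this assay. It differs from compound 3 in one place: chloro in place of methyl on an aromatic carbon. Among the compounds with values here, no step between two measured compounds tracks this exchange, so its size is not known from the series.

The change is expected to give no step beyond the scatter, since compound 3 sits at 0% and compound 1 sits at 0%. For compound 4 the estimate is 5%, with a range from 0% to 20%. The expected step is a number 5 percentage points higher from compound 3 to compound 4 (within the scatter).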

Compound 4, a percentage reported as inhibition, at one concentration (the size of the read-out at that concentration, not a potency): 27%
Beside the measured number, compound 4's estimate is 22 percentage points below it; the measured number lies above the stated range.
By their numbers in this assay, from the lowest: compounds 1 and 3 (each within the scatter of the next); then compounds 2 and 4 (each within the scatter of the next).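

Within the data shown here, the exchange of chloro in place of methyl on an aromatic carbon gives a number 27 percentage points higher from compound 3 to compound 4 (beyond the scatter) in this assay and is the first single-place change that can be read as a step. It shows that this place, para to a large group, is not silent in this read-out: swapping one heavy atom for one heavy atom, with no hydrogen-bond donor or acceptor entering or leaving, is enough to move the number from the bottom of the series. The step rests on one pair at a single concentration, so it says nothing about potency, and no measurement on hand bears on why it occurs.

From the compounds shown here alone, what remains open is whether the step belongs to chloro alone or would also appear with fluoro, bromo, methoxy or an amine at this place. Also open, going by these compounds, is how a bare hydrogen at this place would read beside chloro and methyl, and whether the same exchange on an aromatic carbon elsewhere on the ring would give a step of similar size.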